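A few compounds are considered here, and "the series" means these few. Any claim that something is new, unique, unknown or untested is made for them only; others in the source may bear on it.

Compound 1 `Cc1cc(C)nc(SCc2cc(=O)c3cc(Cl)ccc3o2)n1` was examined in a functional assay on MDA-MB-435S cells (Homo sapiens) for cytotoxicity, read by MTT assay, with a stated time of 72 h; a higher number here means a weaker inhibitor, a lower number a stronger inhibitor. In this assay compound 1 gives only a limit, > 25000 nM, so its standing rests on the limit of > 25000 nM in this assay, at which 1 of the 2 values shown sits, rather than on a number. Among the compounds with values here, compound 2 `O=c1c(CSc2cc(=O)c3ccccc3s2)coc2ccccc12` shares no single-point step with compound 1; in this assay compound 2 gives 1700 nM. Compound 3 `Cc1cc(C)nc(SCc2cc(=O)c3ccccc3o2)n1` differs from compound 1 by hydrogen in place of chloro on an aromatic carbon. Within the data shown here, no measured step gauges this change. The step from compound 1 to compound 3 is expected to be a step that the limit leaves unreadable from compound 1 to compound 3, within the scatter. Compound 3 is therefore estimated at 30000 nM, between 8000 nM and 100000 nM.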

Compound 3, half-maximal inhibitory concentration: > 25000 nM
Compound 3 gave a limit, no number; the forecaster's own chance of this, stated with the estimate: 70%; the middle value does not contradict the limit.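

Compound 1 and compound 3 each give only a limit in this assay, so no step between them can be read: the limit of > 25000 nM in this assay, at which 2 of the 3 values shown sit.

The compounds shown leave open whether hydrogen in place of chloro on an aromatic carbon alters the read-out at all.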